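Macrocyclic hydroxamates: amide carbonyl added at ring nitrogen

The source may report more compounds than this note shows. Statements on the series, on what has been measured and on what is new or still open speak of the compounds shown alone.

The series is followed in a functional assay on HEL cells (Homo sapiens) for inhibition, read by CellTiter-Glo, with a stated time of 48 h; a lower number here means a stronger inhibitor of growth, a higher number a weaker inhibitor of growth. Two members have been measured. Compound 1 `O=C(CCCCN1C/C=C/CCOc2cccc(c2)-c2ccnc(n2)Nc2cccc(c2)C1)NO` gives 510 nM in this assay, and compound 2 `O=C(CCCCCCN1C/C=C/COCc2cccc(c2)-c2ccnc(n2)Nc2cccc(c2)C1)NO` gives 700 nM in this assay; the two numbers are within the usual scatter of each other, so the measured set so far shows no difference that can be read as a change.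

Compound 3 `O=C(CCCCC(=O)N1C/C=C/CCOc2cccc(c2)-c2ccnc(n2)Nc2cccc(c2)C1)NO` is the next member to be measured in this assay. It differs from compound 1 in one place: (4-(hydroxycarbamoyl)butyl)carbonyl in place of 4-(hydroxycarbamoyl)butyl on an amine nitrogen in a ring. The change sits on an amine nitrogen in a ring of the shared core; the rest of the structure is kept.

For the measured compounds named here, no step between measured compounds touches this position, so the size of the step is open. The expectation is a modest step, estimated at a 1.6-fold higher number from compound 1 to compound 3 (0.20 log units; within the scatter), with the direction toward a somewhat higher number, though a result within the scatter of compound 1 would not surprise. Compound 3 is estimated at 800 nM in this assay, with a range from 300 nM to 2500 nM.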

Compound 3, concentration for 50% growth inhibition: 2110 nM
Compound 3: the middle estimate sits 2.6-fold (0.42 log units) below what was measured, and the stated range covers the measured number.
By their numbers in this assay, from the lowest: compounds 1 and 2 (each within the scatter of the next); then compound 3.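

Working notes: this is the first step at the amine nitrogen in a ring of the shared core. In this assay, (4-(hydroxycarbamoyl)butyl)carbonyl in place of 4-(hydroxycarbamoyl)butyl gives a 4.1-fold higher number from compound 1 to compound 3 (0.62 log units; beyond the scatter), so this position responds to the change and growth inhibition is weaker with the carbonyl in place. No data bear on the reason for this step.

As far as these compounds go, it remains open whether a longer chain ending in the same hydroxycarbamoyl group would show a step of similar size when joined to the ring nitrogen through a carbonyl. From the compounds shown here alone, it is also open how a sulfonyl link at this nitrogen would compare with both the carbonyl of compound 3 and the plain chain of compound 1.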